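Swapping a Phenyl for Furan-2-yl on the Weakest Compound

This account rests on a few compounds, and the source may have more. Where it says the series, first, only, none or still open, it means among the compounds named here.

The measured compounds share one core and have been tested in an assay on cells for inhibition of histone deacetylase 4 (Homo sapiens), read by fluorescence, with a stated time of 30 min; a lower number here means a stronger inhibitor, a higher number a weaker inhibitor. Compound 1, `O=C1NC(=O)/C(=C\c2ccc(OCC(=O)N3N=C(c4ccccc4)CC3c3ccccc3)cc2)S1`, gives 1600 nM. Compound 2, `O=C1NC(=O)/C(=C\c2ccc(OCC(=O)N3N=C(c4ccccc4)CC3c3ccc(Br)cc3)cc2)S1`, carries a bromo in place of hydrogen on an aromatic carbon and gives 1200 nM; the change a 1.3-fold lower number from compound 1 to compound 2 (0.12 log units; within the scatter) is within the scatter, so no order between the two can be read. Compound 3, `O=C1NC(=O)/C(=C\c2ccc(OCC(=O)N3N=C(c4ccc(F)cc4)CC3c3ccccc3)cc2)S1`, carries a fluoro in place of hydrogen on an aromatic carbon and gives 4200 nM; the change a 2.6-fold higher number from compound 1 to compound 3 (0.42 log units; beyond the scatter) is beyond the scatter, and compound 3 is the weakest inhibitor of the group, its number lying beyond the scatter above both others.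

Compound 4, `O=C1NC(=O)/C(=C\c2ccc(OCC(=O)N3N=C(c4ccc(F)cc4)CC3c3ccco3)cc2)S1`, differs from compound 3 in one place: furan-2-yl in place of phenyl on a saturated ring carbon. For the measured compounds named here, no measured step changes that ring itself; the only step touching it, from compound 1 to compound 2, only added a bromo and stayed within the scatter, and the fluoro step concerns the other ring. There is therefore no direct guide, and no shift beyond the scatter is expected: the step of a 1.1-fold lower number from compound 3 to compound 4 (0.02 log units; within the scatter) is an estimate resting on the absence of contrary evidence. Compound 4 is expected at about 4000 nM, within a range of 1500 nM to 11000 nM.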

Compound 4, half-maximal inhibitory concentration: 880 nM
The estimate for compound 4 lay 4.5-fold (0.66 log units) above the measured number; the measured number lies below the stated range.
By their numbers in this assay, from the lowest: compounds 4, 2 and 1 (each within the scatter of the next); then compound 3.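

In this assay, the group on the saturated ring carbon next to the ring nitrogen can clearly shift the number: furan-2-yl in place of phenyl gives a 4.8-fold lower number from compound 3 to compound 4 (0.68 log units; beyond the scatter), a modest step beyond the scatter. For the compounds shown here, the earlier compounds did not show this, since the only change touching that ring, a bromo added to the phenyl, gave a 1.3-fold lower number from compound 1 to compound 2 (0.12 log units; within the scatter), which stays within the scatter; exchanging the whole ring, a six-membered ring of carbon only for a five-membered ring containing oxygen, shows what adding a substituent did not. No measurement shown here explains the shift, and this single step cannot separate the effect of ring size from that of the oxygen.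

As far as these compounds go, the furan-2-yl change is seen only alongside the 4-fluorophenyl group, so whether it would give a similar step with the plain phenyl of compound 1 remains open. From the compounds shown here alone, it is also open how this position would respond to thiophen-2-yl, which would keep the five-membered ring but replace the oxygen with sulfur, or to cyclohexyl, a ring that is not aromatic.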